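Bromo for methyl on the aromatic ring: expected inhibition

A few compounds are considered here, and "the series" means these few. Any claim that something is new, unique, unknown or untested is made for them only; others in the source may bear on it.

Of the compounds shown here, two have been tested in a functional assay on the whole organism for inhibition, with Rattus norvegicus as the target, at a dose of 30 mg/kg; a lower number here means less inhibition, a higher number more inhibition at the dose given (going by the name of the read-out). Compound 1, `CCOCCC/N=C(\S)n1ncnc1N`, gives 1% in this assay. Compound 2, `C/N=C(\S)n1nc(-c2ccc(C)cc2)nc1N`, gives 65%. On these two numbers compound 2 stands highest, and the gap to compound 1 is beyond the usual scatter; since the two structures differ in several places at once, nothing more can be read from that gap than what the two values show.

Compound 3, `C/N=C(\S)n1nc(-c2ccc(Br)cc2)nc1N`, is the next member to go into this assay. It differs from compound 2 in a single place: bromo in place of methyl on an aromatic carbon. The group that leaves and the group that enters are each a single heavy atom, with no change in ring count, in hydrogen-bond donors or acceptors, or in charge.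

Going by the values given here, no step between measured compounds is at hand to calibrate this change. The expectation is a small step from compound 2 to compound 3 in this assay, a number 5 percentage points lower from compound 2 to compound 3 (within the scatter), not clearly beyond the scatter in either direction. Compound 3 is therefore estimated at 60%, with a range from 35% to 85%.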

Compound 3, a percentage reported as inhibition, in the whole organism at one dose (the size of the read-out at that dose, not a potency): 88%
For compound 3 the middle estimate is 28 percentage points below the measured one; measured number outside the range, above it.
By their numbers in this assay, from the lowest: compound 1; then compound 2; then compound 3.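

In this assay, going by these compounds alone, bromo in place of methyl on an aromatic carbon, para to a large group, gives a number 23 percentage points higher from compound 2 to compound 3 (beyond the scatter) and provides the first comparison that isolates one place. The earlier pair differed in several places at once, whereas this step shows that the read-out at this position responds to the identity of the group alone. The response appears with a swap of one heavy atom for another, with no change in ring count, hydrogen-bond donors, hydrogen-bond acceptors or net charge, and no measurement at hand bears on the reason for it.

With only methyl and bromo shown at this position, no trend across groups can be drawn, and how an amine, a carboxylic acid or a longer chain there would read in this assay remains open. Going by these compounds, compound 1 differs from compound 2 and from compound 3 in several places, so what its chain and the absence of an aromatic ring each contribute also remains open, as does whether the step from methyl to bromo would hold on a different chain.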